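The source may report more compounds than this note shows. Statements on the series, on what has been measured and on what is new or still open speak of the compounds shown alone.

Compound 1 `O=[N+]([O-])c1cn2c(n1)OCC(COc1ccc(-c3ccc(OC(F)(F)F)cc3)cc1)C2` and compound 2 `O=[N+]([O-])c1cn2c(n1)OCC(COc1ccc(-c3ccc(C(F)(F)F)cc3)cc1)C2` share one core and differ in a single place: trifluoromethyl in place of trifluoromethoxy on an aromatic carbon. In an ADME assay on Vero cells (Chlorocebus sabaeus) for cytotoxicity, with a stated time of 72 h (a lower number here means a stronger inhibitor, a higher number a weaker inhibitor), compound 1 gives > 128000 nM, which is a limit of the assay and not a number. Compound 2 gives > 128000 nM, likewise a limit. The step that the two limits leave unreadable from compound 1 to compound 2 is therefore unreadable. Compound 3 `O=[N+]([O-])c1cn2c(n1)OCC(COc1ccc(-c3ccc(OC(F)(F)F)cc3)nc1)C2` carries the same trifluoromethoxy group on another core; the difference between the two cores is not broken down here. In this assay compound 3 gives > 128000 nM, again a limit. Compound 4 `O=[N+]([O-])c1cn2c(n1)OCC(COc1ccc(-c3ccc(C(F)(F)F)cc3)nc1)C2` is not yet measured and differs from compound 3 in that (trifluoromethyl in place of trifluoromethoxy on an aromatic carbon), the same change as from compound 1 to compound 2. Because the limit of > 128000 nM in this assay, at which 3 of the 3 values shown sit, the expected step is a step that the limit leaves unreadable from compound 3 to compound 4. Compound 4 is expected at 200000 nM, between 128000 nM and 500000 nM.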

Compound 4, half-maximal inhibitory concentration: > 128000 nM
Compound 4 gave a limit, no number; the forecaster's own chance of this, stated with the estimate: 90%; the middle value does not contradict the limit.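

In this assay no step can be read from compound 3 to compound 4, because both give only a limit and no number: the limit of > 128000 nM in this assay, at which 4 of the 4 values shown sit. The compounds shown leave open whether trifluoromethyl in place of trifluoromethoxy changes the half-maximal inhibitory concentration at all.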